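Cytotoxicity notes on a shared-core series

The source may report more compounds than this note shows. Statements on the series, on what has been measured and on what is new or still open speak of the compounds shown alone.

In an ADME assay on HepG2 2.2.15 cells (Homo sapiens) for cytotoxicity (on this read-out higher numbers stand for lower toxicity in this test and lower numbers for higher toxicity in this test), compound 1 `CC(C)(C)OC(=O)Nc1ncc(C(Oc2ccc3cc(Br)ccc3c2)c2ccc(Cl)cc2)s1` sits at a limit of the assay, > 50000 nM. Compound 2 `COCCCNc1ncc(C(Oc2ccc3cc(Br)ccc3c2)c2ccc(Cl)cc2)s1` is recorded in this assay as "not toxic" (no number reported), with no number behind it, so it stands only beside (the limit of > 50000 nM in this assay, at which 1 of the 2 values shown sits). Compound 3 `COC(=O)CCCCNc1ncc(C(Oc2ccc3cc(Br)ccc3c2)c2ccc(Cl)cc2)s1` carries (methoxycarbonyl)methyl in place of methoxy on a saturated chain carbon, three bonds along the chain from a nitrogen on an aromatic ring. Among the compounds with values here, no measured step covers this change, and no shift beyond the usual scatter is expected in this assay in either direction. Compound 3 is estimated at 50000 nM, within 20000 nM to 100000 nM, and will most likely again be reported only as a limit.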

Compound 3, half-maximal cytotoxic concentration: "not toxic" (no number reported)
The entry for compound 3 holds no number, so the estimate cannot be set against anything.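

Compound 2 and compound 3 are both recorded as "not toxic" with no number in this assay, so no step can be read between them. The compounds shown leave open how far the chain change could shift cytotoxicity, as the only figure is a limit: the limit of > 50000 nM in this assay, at which 1 of the 3 values shown sits.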